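Chloro to Fluoro on a Shared Aryl Ring in Two Cores

A few compounds are considered here, and "the series" means these few. Any claim that something is new, unique, unknown or untested is made for them only; others in the source may bear on it.

Measured compounds in a functional assay on HCT-116 cells (Homo sapiens) for antiproliferative activity; a lower number here means a stronger inhibitor of growth, a higher number a weaker inhibitor of growth:
compound 1 `Cc1cc(C)c2c(O)cc(-c3cccc(F)c3)nc2n1`, < 10 nM
compound 2 `Cc1cc(C)c2c(O)cc(-c3cccc(Cl)c3)nc2n1`, 170 nM
compound 3 `Cc1cnc2[nH]c(-c3cccc(Cl)c3)cc(=O)c2c1`, 30.2 nM

In this assay compound 1 gives < 10 nM, which is a limit of the assay and not a number (the limit of < 10 nM in this assay, at which 1 of the 3 values shown sits). Compound 2 gives 170 nM, and the step of an at least 17-fold lower number from compound 2 to compound 1 (1.23 log units; beyond the scatter) is the change (fluoro in place of chloro on an aromatic carbon). Compound 3 gives 30.2 nM; how its core differs from that of compound 2 is not broken down here. Compound 4 `Cc1cnc2[nH]c(-c3cccc(F)c3)cc(=O)c2c1` has not been measured in this assay. It differs from compound 3 by fluoro in place of chloro on an aromatic carbon, the same change as that from compound 2 to compound 1. On the strength of that earlier step, a step of similar direction is expected, a 6.0-fold lower number from compound 3 to compound 4 (0.78 log units; beyond the scatter). Compound 4 is therefore estimated at 5 nM, between 1.5 nM and 15 nM.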

Compound 4, concentration for 50% growth inhibition: 24 nM
Compound 4: middle estimate off by 4.8-fold (0.68 log units), on the low side; measured number outside the range, above it.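

Fluoro in place of chloro gives a 1.3-fold lower number from compound 3 to compound 4 (0.10 log units; within the scatter) in this assay and so brings no clear change on this core, unlike the large step seen on the other core. The size of the step therefore did not carry over from one core to the other: the same change on two cores in this assay, an at least 17-fold lower number (1.23 log units; beyond the scatter) from compound 2 to compound 1 and a 1.3-fold lower number (0.10 log units; within the scatter) from compound 3 to compound 4, at least 13-fold (1.13 log units) apart, beyond the scatter of two such steps. Compound 1 gives < 10 nM as a limit of the assay and not a number, so the size of the earlier step is not fixed, and two cores say nothing about how the change would behave on a third.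

The compounds shown leave open how a methoxy group, a nitrile or an amine on the same aromatic carbon would fare on either core. They also leave open which part of the difference between the two cores goes with the differing steps.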